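A Fluorophenyl Amide Tested for Vero Cell Toxicity

The source may report more compounds than this note shows. Statements on the series, on what has been measured and on what is new or still open speak of the compounds shown alone.

Compound 1 `CSCC(=O)N1CCN(c2nc(=O)c3cc(C(F)(F)F)cc([N+](=O)[O-])c3s2)CC1` in an ADME assay on Vero cells (Chlorocebus sabaeus) for cytotoxicity, read by MTT assay, with a stated time of 72 h (on this read-out lower numbers stand for higher toxicity in this test and higher numbers for lower toxicity in this test), gives > 125000 nM, a limit of the assay.
Compound 2 `CC(C)(C)C(=O)N1CCN(c2nc(=O)c3cc(C(F)(F)F)cc([N+](=O)[O-])c3s2)CC1` in this assay gives > 125000 nM, likewise a limit.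
Compound 3 `O=C(c1ccccc1Cl)N1CCN(c2nc(=O)c3cc(C(F)(F)F)cc([N+](=O)[O-])c3s2)CC1` in this assay gives > 125000 nM, again a limit.

Compound 1 therefore stands only at a limit, and the whole series sits at the same one (the limit of > 125000 nM in this assay, at which 3 of the 3 values shown sit). The new compound 4 `O=C(c1ccc(F)cc1)N1CCN(c2nc(=O)c3cc(C(F)(F)F)cc([N+](=O)[O-])c3s2)CC1` differs from compound 1 by 4-fluorophenyl in place of (methylsulfanyl)methyl on a carbonyl carbon. The measured steps a step that the two limits leave unreadable from compound 1 to compound 2, a step that the two limits leave unreadable from compound 1 to compound 3 and a step that the two limits leave unreadable from compound 2 to compound 3 show that changing the group on the carbonyl carbon has so far produced nothing readable. The expected step is therefore a step that the limit leaves unreadable from compound 1 to compound 4, with compound 4 most likely reported as a limit. Compound 4 is estimated at 150000 nM, ranging from 80000 nM to 400000 nM.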

Compound 4, half-maximal cytotoxic concentration: > 125000 nM
Compound 4 gave a limit, no number; the forecaster's own chance of this, stated with the estimate: 85%; the middle value lies beyond the limit too.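

Compound 4, like compound 1, compound 2 and compound 3, gives only a limit, so no step among these compounds can be read in this assay here. The compounds shown leave open whether any group on the carbonyl carbon changes the toxicity.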